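This account rests on a few compounds, and the source may have more. Where it says the series, first, only, none or still open, it means among the compounds named here.

Measured so far in a functional assay on HEK293 cells for positive allosteric modulation of metabotropic glutamate receptor 5 (Homo sapiens), read by FLIPR and calcium flux; a lower number here means that less compound is needed, a higher number that more compound is needed for the effect:
compound 1 `O=C(COCc1cccnc1)N1CCN(c2ccc(Cl)cc2Cl)CC1` gives 1090 nM
compound 2 `O=C(COCc1ncccn1)N1CCN(c2ccc(Cl)cc2Cl)CC1` gives 18000 nM

Compound 2 stands with the highest of these two numbers; its nearest neighbour is compound 1, and the step of a 17-fold higher number from compound 1 to compound 2 (1.22 log units; beyond the scatter) shows how strongly the ring at this position shifts the read-out. Compound 3 `O=C(COCc1cncs1)N1CCN(c2ccc(Cl)cc2Cl)CC1` differs from compound 2 by 1,3-thiazol-5-yl in place of pyrimidin-2-yl on a saturated chain carbon bound to an oxygen on a saturated carbon. For the measured compounds named here, no measured step exchanges a six-membered ring for a five-membered one, so only that single large step bears on the case, and the direction is uncertain. Compound 3 is nevertheless expected to show a step of a 4.5-fold lower number from compound 2 to compound 3 (0.65 log units; beyond the scatter). The estimate for compound 3 is 4000 nM, between 800 nM and 20000 nM.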

Compound 3, half-maximal effective concentration: 1280 nM
Compound 3: the middle estimate sits 3.1-fold (0.49 log units) above what was measured, within the range that was stated.
By their numbers in this assay, from the lowest: compounds 1 and 3 (each within the scatter of the next); then compound 2.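

In this assay there is a 14-fold lower number from compound 2 to compound 3 (1.15 log units; beyond the scatter) and so the high number does not extend to every ring at this place. With a 1.2-fold higher number from compound 1 to compound 3 (0.07 log units; within the scatter) the five-membered 1,3-thiazol-5-yl and the six-membered pyridin-3-yl cannot be told apart, while pyrimidin-2-yl alone stands apart, so ring size by itself does not set the number among these three compounds. No measured evidence bears on why pyrimidin-2-yl differs from the other two. Open, on these data alone, is how a plain phenyl ring, or a saturated amine such as piperidin-4-yl, would behave on this saturated chain carbon.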